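The source may report more compounds than this note shows. Statements on the series, on what has been measured and on what is new or still open speak of the compounds shown alone.

Values in a functional assay on MDA-MB-231 cells (Homo sapiens) for antiproliferative activity, read by MTT assay, with a stated time of 72 h (on this read-out lower numbers stand for stronger inhibition and higher numbers for weaker inhibition), for the measured compounds
- compound 1 `CC(=O)O[C@H]1CC[C@]2(C)[C@H](CC[C@@](C)(O)[C@H]2CC[C@@H]2C(C)=CC[C@H]3[C@H](CC[C@]3(C)O)C2(C)C)OC1(C)C` gives 38000 nM
- compound 2 `CC1=CC[C@H]2[C@H](CC[C@]2(C)O)C(C)(C)[C@@H]1CC[C@H]1[C@]2(C)CC[C@H](OC(=O)NCc3ccccc3)C(C)(C)O[C@H]2CC[C@@]1(C)O` gives 40300 nM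
- compound 3 `CC1=CC[C@H]2[C@H](CC[C@]2(C)O)C(C)(C)[C@@H]1CC[C@H]1[C@]2(C)CC[C@H](OC(=O)NS(=O)(=O)c3ccc(C)cc3)C(C)(C)O[C@H]2CC[C@@]1(C)O` gives 47100 nM

Compound 3 stands within the scatter of the other two compounds, as the steps show (a 1.2-fold higher number from compound 1 to compound 3 (0.09 log units; within the scatter) and a 1.2-fold higher number from compound 2 to compound 3 (0.07 log units; within the scatter)). The next entry is compound 4 `COc1ccc(C(=O)O[C@H]2CC[C@]3(C)[C@H](CC[C@@](C)(O)[C@H]3CC[C@@H]3C(C)=CC[C@H]4[C@H](CC[C@]4(C)O)C3(C)C)OC2(C)C)cc1` and its difference from compound 3 is this: 4-methoxyphenyl in place of ((4-methylphenyl)sulfonyl)amino on a carbonyl carbon.

All three measured steps bear on this change, since each alters the group on that same carbonyl carbon or on the amide-type nitrogen attached to it. Benzylamino in place of methyl gives a 1.1-fold higher number from compound 1 to compound 2 (0.03 log units; within the scatter) and the step between the two nitrogen substituents is a 1.2-fold higher number from compound 2 to compound 3 (0.07 log units; within the scatter) as well. None of these separates the compounds beyond the scatter. Going by the values given here, no measured compound carries 4-methoxyphenyl on that carbonyl carbon, so the expectation is an extrapolation from three closely spaced values.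

No step beyond the scatter is expected in this assay here. The estimated step is a 1.1-fold lower number from compound 3 to compound 4 (0.05 log units; within the scatter) and it stays within the scatter. For compound 4 the estimated value is 42000 nM with an expected range from 20000 nM to 85000 nM in this read-out.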

Compound 4, half-maximal inhibitory concentration: 30600 nM
Estimate against measurement, compound 4: 1.4-fold (0.14 log units) above; measured number inside the range.
By their numbers in this assay, from the lowest: compounds 4, 1, 2 and 3 (each within the scatter of the next).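

In this assay, compound 4 gives 30600 nM, so the carbonyl carbon can carry an aromatic ring directly, with no amide-type nitrogen, and the number still does not move beyond the scatter: the change from ((4-methylphenyl)sulfonyl)amino to 4-methoxyphenyl is a 1.5-fold lower number from compound 3 to compound 4 (0.19 log units; within the scatter), the change from benzylamino is a 1.3-fold lower number from compound 2 to compound 4 (0.12 log units; within the scatter), and the change from methyl is a 1.2-fold lower number from compound 1 to compound 4 (0.09 log units; within the scatter). The earlier compounds shown here covered only methyl and two nitrogen-linked groups, whereas this result extends the same flat picture to a group without that nitrogen, and all four compounds now lie within the scatter of one another. No measurement available here accounts for this lack of separation.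

Going by these compounds, it remains open whether any group on this carbonyl carbon, such as a morpholine, a longer alkyl chain or a phenyl ring bearing a carboxylic acid, would give a step beyond the scatter. On these data alone, it is also open what the free hydroxyl in place of the whole ester or carbamate would give, and whether changes to the shared core itself would shift these numbers.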